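Swapping the ester alkyl group on a furan-bearing core

The source may report more compounds than this note shows. Statements on the series, on what has been measured and on what is new or still open speak of the compounds shown alone.

Measured so far in an assay on membranes from HEK293 cells for displacement of a labelled ligand from adenosine receptor A2b (Homo sapiens), read by scintillation counting, with a stated time of 30 min; a higher number here means a weaker inhibitor, a lower number a stronger inhibitor:
- compound 1 `CC1=C(C(=O)OC(C)(C)C)C(c2ccoc2)NC(=O)N1`: 4440 nM
- compound 2 `CC1=C(C(=O)CC(C)C)C(c2ccsc2)NC(=O)N1`: 1000 nM
- compound 3 `CC1=C(C(=O)OC2CCCC2)C(c2ccco2)NC(=O)N1`: 577 nM

Among these three, compound 1 gives the highest number in this assay, and so the weakest inhibition. Its closest neighbour is compound 2, whose number is lower by a margin beyond the usual scatter; compound 3 lies further away still, with the lowest number of the three. No pair of these compounds differs in only one place, so no single-point comparison is available from them.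

Compound 4 `CCC(C)OC(=O)C1=C(C)NC(=O)NC1c1ccoc1` has not been measured yet. It differs from compound 1 in one spot only: sec-butyl in place of tert-butyl on an oxygen next to a carbonyl group. The two compounds contain the same atoms, joined differently.

Going by the values given here, nothing among the measured compounds tests this exact exchange on an oxygen next to a carbonyl group, so the expectation rests on compound 1 alone. In this assay the expected step is a 1.5-fold lower number from compound 1 to compound 4 (0.17 log units; within the scatter), a shift that may well stay within the scatter. Compound 4 is therefore estimated at 3000 nM, with a plausible range from 1000 nM to 9000 nM.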

Compound 4, inhibition constant: 201 nM
Compound 4: middle estimate off by 15-fold (1.17 log units), on the high side; the measured number lies below the stated range.
By their numbers in this assay, from the lowest: compound 4; then compounds 3 and 2 (each within the scatter of the next); then compound 1.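

In this assay, turning the tert-butyl group into sec-butyl gives a 22-fold lower number from compound 1 to compound 4 (1.34 log units; beyond the scatter) and counts as a large step. This place on the molecule therefore responds strongly to how the four carbons of the group are joined, even though the two compounds contain the same atoms and the count of heavy atoms in the group stays the same. Nothing available here explains why this rearrangement of the same atoms has so large an effect.

On these data alone, this step is seen on the core of compound 1 alone, so whether it carries over to a different group on the shared core remains open. Also open, as far as these compounds go, is how a longer chain such as n-hexyl, or a carboxylic acid in place of the ester, would compare with sec-butyl.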